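The source may hold more compounds than are shown below. What is called first, only, known or untested is meant among the compounds shown, and "the series" means these compounds.

Compound 1 (`COc1ccc(-c2cc3c(OC)cc(OC)cc3n(CCCC#N)c2=O)cc1`) and compound 2 (`COc1ccc(-c2cc3c(OC)cc(OC)cc3n(CC(=O)OCc3ccccc3)c2=O)cc1`) share one core. In a functional assay on PC-3 cells (Homo sapiens) for cytotoxicity, read by colorimetric assay and MTT assay (a higher number here means a weaker inhibitor, a lower number a stronger inhibitor), compound 1 gives 10000 nM and compound 2 gives 10000 nM (level at these digits). For the measured compounds named here, the only measured step (no change at the digits printed from compound 1 to compound 2 (within the scatter)) swapped one group for another and moved nothing beyond the scatter. Compound 3 (`COc1ccc(-c2cc3c(OC)cc(OC)cc3n(CC(=O)O)c2=O)cc1`) differs from compound 2 by one change (hydrogen in place of benzyl on an oxygen next to a carbonyl group), benzyloxycarbonyl to carboxy. Going by the values given here, no measured compound carries a carboxy, so that single step is thin evidence. The expected change (no change at the digits printed from compound 2 to compound 3 (within the scatter)) in this assay is therefore none beyond the scatter. For compound 3 the estimated value is 10000 nM in an expected range of 4000 nM to 20000 nM overall.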

Compound 3, half-maximal inhibitory concentration: 10000 nM
Compound 3: middle estimate and measured number agree at the digits printed; measured number inside the range.
By their numbers in this assay, from the lowest: compounds 1, 2 and 3 (each within the scatter of the next).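

In this assay, hydrogen in place of benzyl on an oxygen next to a carbonyl group gives no change at the digits printed from compound 2 to compound 3 (within the scatter), so losing that whole aromatic ring leaves the reading where it was. The carboxy group also gives no change at the digits printed from compound 1 to compound 3 (within the scatter), which means that none of the three groups on this chain separates from the others. Nothing available explains this flat result. As far as these compounds go, whether any group at this position can give a stronger inhibitor stays open; an amine or an amide on this chain would test that.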